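Inverting the chain stereocentre of compound 2

A few compounds are considered here, and "the series" means these few. Any claim that something is new, unique, unknown or untested is made for them only; others in the source may bear on it.

Compound 1 `CC(C)C[C@@H](N)C(=O)Nc1cc2cc[nH]c(=O)c2cc1Cl` (700 nM)
Compound 2 `CC(C)[C@@H](N)C(=O)Nc1cc2cc[nH]c(=O)c2cc1Cl` ("not determined" (no result reported))

Going by the values given here, in a functional assay (aorta) with Rattus norvegicus as the target (a higher number here means that more compound is needed for the effect, a lower number that less compound is needed), compound 1 gives the only number in this small set (700 nM). The entry for compound 2 reads "not determined" (no result reported) and no result was reported, so compound 2 has no position on the scale. Compound 3 `CC(C)[C@H](N)C(=O)Nc1cc2cc[nH]c(=O)c2cc1Cl` is the stereoisomer of compound 2 (the two compounds have the same atoms and bonds and differ only in configuration as drawn: 1 of 1 stereo elements differ; a stereocentre at a saturated chain carbon is drawn R in compound 2 and S in compound 3). Among the compounds with values here, no measured pair shows what such an inversion does in this assay, and no step from compound 2 can be calculated. The closest guide is compound 1 (700 nM), although it is not the same compound. A value of similar order is expected, with the direction of any difference left open and a gap beyond the scatter quite possible. Compound 3 is expected near 800 nM in an estimated range (from 150 nM to 4000 nM) that remains wide.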

Compound 3, half-maximal effective concentration: 500 nM
Estimate against measurement, compound 3: 1.6-fold (0.20 log units) above; the range from low to high includes it.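

In this assay, 1-amino-2-methylpropyl in place of 1-amino-3-methylbutyl on a carbonyl carbon gives a 1.4-fold lower number from compound 1 to compound 3 (0.15 log units; within the scatter), so this assay does not separate the two side chains. Going by these compounds alone, compound 3 therefore provides the first number for the 1-amino-2-methylpropyl chain, and that number stays within the usual scatter of the value for compound 1. The step from compound 2 to compound 3 cannot be read, although it would have isolated configuration alone: the fact that compounds 2 and 3 differ only in the configuration as drawn.

Going by these compounds, the effect of inverting this stereocentre therefore remains open, including whether the form drawn R would give a value close to that of compound 3. Also open, on these data alone, is how the assay would respond at this position to a carboxylic acid on the side chain, a longer chain such as hexyl, or an acetamide in place of the free amine.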